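The source may hold more compounds than are shown below. What is called first, only, known or untested is meant among the compounds shown, and "the series" means these compounds.

Compound 1 `CN1CCN(c2nc(-c3cccc(Cl)c3)nc3[nH]cnc23)CC1`: 29.9%
Compound 2 `CN1CCN(c2nc(-c3ccc(Cl)c(C(F)(F)F)c3)nc3[nH]cnc23)CC1`: 25.1%
Compound 3 `CN1CCN(c2nc(-c3cccc(O)c3)nc3[nH]cnc23)CC1`: 27%

In an assay on cells for displacement of a labelled ligand from adenosine receptor A2b (Homo sapiens), read by scintillation counting and radioligand binding, with a stated time of 30 min, tested at 10 uM (a higher number here means more inhibition at the concentration tested (going by the name of the read-out), a lower number less inhibition), compound 3 gives 27%, a number that lies within the scatter of both compound 1 and compound 2, so the three measured compounds cannot be told apart. For the measured compounds named here, the single measured step that touches this series is a number 2.9 percentage points lower from compound 1 to compound 3 (within the scatter), itself within the scatter. Compound 4 `CN1CCN(c2nc(-c3ccc(Cl)cc3)nc3[nH]cnc23)CC1` carries the change (4-chlorophenyl in place of 3-hydroxyphenyl on an aromatic carbon). Going by the values given here, no measured pair shows a chloro moving from one ring position to another; the only related step exchanges hydroxy for chloro and changes nothing beyond the scatter. Compound 4 is therefore expected to show a step of a number 1 percentage points higher from compound 3 to compound 4 (within the scatter), none beyond the scatter. The estimate for compound 4 is 28%, with a range from 15% to 41%.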

Compound 4, a percentage reported as inhibition, at one concentration (the size of the read-out at that concentration, not a potency): 6.2%
Beside the measured number, compound 4's estimate is 21.8 percentage points above it, outside the stated range (below it).
By their numbers in this assay, from the lowest: compound 4; then compounds 2, 3 and 1 (each within the scatter of the next).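

In this assay, for the compounds shown here, moving the chloro of the 3-chlorophenyl group to give the 4-chlorophenyl group produces a number 23.7 percentage points lower from compound 1 to compound 4 (beyond the scatter), the first step beyond the scatter. The other two steps agree: a number 20.8 percentage points lower from compound 3 to compound 4 (beyond the scatter) and a number 18.9 percentage points lower from compound 2 to compound 4 (beyond the scatter), the latter with hydrogen in place of trifluoromethyl. Among these compounds, then, only compound 4 lacks a group where the 3-chlorophenyl and 3-hydroxyphenyl rings carry theirs, and none goes against this pattern. No evidence here explains the loss. Open, going by these compounds, is whether a 3-methoxyphenyl or 3-aminophenyl group would hold the higher numbers, and what a plain phenyl would give.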